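The source may report more compounds than this note shows. Statements on the series, on what has been measured and on what is new or still open speak of the compounds shown alone.

Compound 1 `O=C(Nc1ccc(Cl)cc1)NS(=O)(=O)c1cc2ccccc2o1` heads the small set at hand. In a functional assay on the whole organism (Mus musculus) for inhibition, at a dose of 150 mg/kg by the oral route (a lower number here means less inhibition, a higher number more inhibition at the dose given (going by the name of the read-out)), compound 1 gives 84%, the highest of the three numbers; compound 2 `O=C(Nc1ccc(Cl)cc1)NS(=O)(=O)c1cc2cc(Cl)ccc2o1` gives 40% and compound 3 `Cc1ccc2oc(S(=O)(=O)NC(=O)Nc3ccc(Cl)cc3)cc2c1` gives 6%, both beyond the scatter below compound 1. The measured steps are all changes on aromatic carbons outside the 4-chlorophenyl group: a number 44 percentage points lower from compound 1 to compound 2 (beyond the scatter), a number 78 percentage points lower from compound 1 to compound 3 (beyond the scatter) and a number 34 percentage points lower from compound 2 to compound 3 (beyond the scatter).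

Compound 4 `Cc1ccc(NC(=O)NS(=O)(=O)c2cc3ccccc3o2)cc1` differs from compound 1 as follows: methyl in place of chloro on an aromatic carbon. Going by the values given here, none of the measured steps touches this six-membered ring, so no step bears directly on it. Among the compounds with values here, the nearest precedent is the same swap at another aromatic carbon, where methyl in place of chloro cost a number 34 percentage points lower from compound 2 to compound 3 (beyond the scatter), and every change made so far has lowered the number. A drop is therefore expected, though its size is uncertain; the expectation is a number 24 percentage points lower from compound 1 to compound 4 (beyond the scatter). Compound 4 is accordingly estimated at 60%, within a range from 25% to 90%.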

Compound 4, a percentage reported as inhibition, in the whole organism at one dose (the size of the read-out at that dose, not a potency): 11%
The estimate for compound 4 lay 49 percentage points above the measured number, and the stated range ends above it.
By their numbers in this assay, from the lowest: compounds 3 and 4 (each within the scatter of the next); then compound 2; then compound 1.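

In this assay, going by these compounds alone, 4-methylphenyl in place of 4-chlorophenyl gives a number 73 percentage points lower from compound 1 to compound 4 (beyond the scatter), so this six-membered ring, untouched by the earlier steps, is also sensitive to change. Methyl in place of chloro lowers the number in both pairs that carry this swap, so its direction holds across these two pairs. Its size, however, does not carry over from one core to the other: the same change on two cores in this assay, a number 34 percentage points lower (beyond the scatter) from compound 2 to compound 3 and a number 73 percentage points lower (beyond the scatter) from compound 1 to compound 4, 39 percentage points apart, beyond the scatter of two such steps

The compounds shown leave open whether the loss belongs to methyl itself or would follow any replacement of chloro at this place, a question that bromo, methoxy or trifluoromethyl there would address. They also cannot tell why the same swap differs in size between the two cores.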